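Cyclopropylmethyl to Propyl on the Ring Nitrogen

The source may report more compounds than this note shows. Statements on the series, on what has been measured and on what is new or still open speak of the compounds shown alone.

Compound 1 `CCCN(CCC)c1c(C)nc(-c2ccc(OC)cc2OC)n(CC2CC2)c1=O` was tested in an assay on IMR-32 cells for binding affinity to corticotropin-releasing factor receptor 1 (Homo sapiens) (a lower number here means a stronger inhibitor, a higher number a weaker inhibitor), and gave 260 nM. Within the data shown here, that is the higher of the two numbers measured so far: compound 2 `CCCN(CCC)c1c(C)nc(-c2c(C)cc(C)cc2OC)n(C)c1=O` gave 90 nM in this assay. Compound 3 `CCCN(CCC)c1c(C)nc(-c2ccc(OC)cc2OC)n(CCC)c1=O` differs from compound 1 by ethyl in place of cyclopropyl on a saturated chain carbon bound to an aromatic nitrogen. Among the measured compounds shown here, no measured pair shows this kind of change. The step from compound 1 to compound 3 is expected to be small, a 1.0-fold lower number from compound 1 to compound 3 (0.02 log units; within the scatter), and may well lie within the usual scatter. Compound 3 is estimated at 250 nM in this assay, with a range from 100 nM to 650 nM.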

Compound 3, inhibition constant in the corticotropin-releasing factor receptor 1 assay: 720 nM
Beside the measured number, compound 3's estimate is 2.9-fold (0.46 log units) below it; measured number outside the range, above it.
By their numbers in the corticotropin-releasing factor receptor 1 assay, from the lowest: compound 2; then compound 1; then compound 3.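

This position is sensitive to what it carries: in the corticotropin-releasing factor receptor 1 assay, the change from cyclopropylmethyl to propyl gives a 2.8-fold higher number from compound 1 to compound 3 (0.44 log units; beyond the scatter), so the intact cyclopropyl ring is the better choice of the two. In a physicochemical assay for solubility, at pH 7.4 (on this read-out lower numbers stand for lower solubility and higher numbers for higher solubility), compound 1 gives 20.1 ug/mL and compound 3 gives 4.9 ug/mL. The same change also lowers the result in the physicochemical assay: the measured solubility of compound 1, 20.1 ug/mL, and of compound 3, 4.9 ug/mL, a 4.1-fold lower number (0.61 log units; beyond the scatter)

Of this pair, then, compound 1 has the better number on both read-outs. From the compounds shown here alone, how a butyl chain or a cyclobutylmethyl group would behave on this aromatic nitrogen stays open, as does whether a hydroxyl group on the chain would shift either read-out.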